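The source may hold more compounds than are shown below. What is called first, only, known or untested is meant among the compounds shown, and "the series" means these compounds.

Within the data shown here, in an ADME assay on CRFK cells (Felis catus) for cytotoxicity (a higher number here means that more compound is tolerated, a lower number that less compound is tolerated), compound 1 (`CCN(CC)CN1C(=O)/C(=N/NC(=S)Nc2ccc(Cl)cc2)c2ccccc21`) gives 4000 nM, the lower of the two numbers so far, and compound 2 (`CCN(CC)CN1C(=O)/C(=N/NC(=S)Nc2ccc(Cl)cc2)c2cc(Cl)ccc21`) gives 9100 nM. Compound 3 (`CCN(CC)CN1C(=O)/C(=N/NC(N)=S)c2ccccc21`) has not yet been measured. Compared with compound 1, it has hydrogen in place of 4-chlorophenyl on an amide-type nitrogen. Among the measured compounds shown here, only one measured step offers any guide, and only indirectly: a 2.3-fold higher number from compound 1 to compound 2 (0.36 log units; beyond the scatter). That step is a chloro in place of hydrogen on an aromatic carbon, not the change at hand. For the measured compounds named here, no measured pair loses the 4-chlorophenyl group, so both size and direction remain uncertain. A modest move to a higher number in this assay is tentatively expected, with no change beyond the scatter still plausible. The expected step is a 2.3-fold higher number from compound 1 to compound 3 (0.35 log units; beyond the scatter). For compound 3, the estimated value is 9000 nM, with an expected range of 3000 nM to 27000 nM.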

Compound 3, half-maximal cytotoxic concentration: 73800 nM
Estimate against measurement, compound 3: 8.2-fold (0.91 log units) below, outside the stated range (above it).
By their numbers in this assay, from the lowest: compound 1; then compound 2; then compound 3.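

In this assay, the amide-type nitrogen carries the larger of the two steps seen so far: hydrogen in place of 4-chlorophenyl gives an 18-fold higher number from compound 1 to compound 3 (1.27 log units; beyond the scatter), whereas the chloro change on the aromatic carbon gives a 2.3-fold higher number from compound 1 to compound 2 (0.36 log units; beyond the scatter). Within this pair, the higher number belongs to the compound without the 4-chlorophenyl group, so that group is not required for a high tolerated concentration. Nothing available accounts for the size of this step.

Still open, from the compounds shown here alone, is whether the step follows the whole ring or only its chlorine; an unsubstituted phenyl, a methyl or a longer alkyl chain on the same nitrogen would separate these cases. Going by these compounds, it is also open whether a chloro on the aromatic carbon of compound 3 would raise the number as it does from compound 1.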